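This account rests on a few compounds, and the source may have more. Where it says the series, first, only, none or still open, it means among the compounds named here.

For the measured compounds named here, compound 1 `Cn1ccc2c(Oc3ccc(NC(=O)c4cn(-c5ccc(Br)cc5)c5ccccc5c4=O)cc3F)ccnc21` is the one compound with a result here: in a functional assay on MCF7 cells (Homo sapiens) for inhibition, read by MTT assay, with a stated time of 72 h (a lower number here means a stronger inhibitor, a higher number a weaker inhibitor), compound 1 gives 1830 nM. Compound 2 `Cn1ccc2c(Oc3ccc(NC(=O)c4cn(-c5ccc(F)c(Cl)c5)c5ccccc5c4=O)cc3F)ccnc21` is a close relative, yet in this assay compound 2 has no reported number "not determined" (no result reported), so it stands on no value at all. Compound 3 `COc1ccc(-n2cc(C(=O)Nc3ccc(Oc4ccnc5c4ccn5C)c(F)c3)c(=O)c3ccccc32)cc1` differs from compound 2 by 4-methoxyphenyl in place of 3-chloro-4-fluorophenyl on an aromatic nitrogen. Going by the values given here, with nothing measured for compound 2, no step from it to compound 3 in this assay can be given a size or a direction, and the result for compound 1 is the only anchor. Compound 3 is expected to come in at an estimated 2500 nM, within a range from 600 nM to 10000 nM.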

Compound 3, half-maximal inhibitory concentration: 6720 nM
Compound 3: the middle estimate sits 2.7-fold (0.43 log units) below what was measured; the range from low to high includes it.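

In this assay, methoxy in place of bromo on an aromatic carbon gives a 3.7-fold higher number from compound 1 to compound 3 (0.56 log units; beyond the scatter), so this position of the aryl group on the aromatic nitrogen responds measurably to the group it carries, and here the change weakens inhibition modestly. The step from compound 2 to compound 3 cannot be read. Nothing available explains this difference.

Going by these compounds, whether 3-chloro-4-fluorophenyl stands nearer to compound 1 or compound 3 remains open. So does how an amine or a carboxylic acid at this place would compare.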